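Triazolylmethyl Spirooxindoles on MCF7 Cells: a Dimethylphenyl Variant

This account rests on a few compounds, and the source may have more. Where it says the series, first, only, none or still open, it means among the compounds named here.

Compound 1 `COc1ccc(-n2nncc2CN2C(=O)C3(C(C#N)=C(N)Oc4c3c3nc5ccccc5nc3c3ccccc43)c3ccccc32)cc1` — in a functional assay on MCF7 cells (Homo sapiens) for antiproliferative activity, read by MTT assay, with a stated time of 48 h (a higher number here means a weaker inhibitor, a lower number a stronger inhibitor), compound 1 gives > 50000 nM, a limit of the assay.
Compound 2 `CCOc1ccccc1-n1nncc1CN1C(=O)C2(C(C#N)=C(N)Oc3c2c2nc4ccccc4nc2c2ccccc32)c2ccccc21` — in this assay compound 2 gives > 50000 nM, a limit of the assay.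
Compound 3 `N#CC1=C(N)Oc2c(c3nc4ccccc4nc3c3ccccc23)C12C(=O)N(Cc1cnnn1-c1ccc(N)cc1)c1ccccc12` — in this assay compound 3 gives > 50000 nM, a limit of the assay.

Compound 1 stands only at a limit in this assay, and every other number shown is a limit as well (the limit of > 50000 nM in this assay, at which 3 of the 3 values shown sit). The steps a step that the two limits leave unreadable from compound 1 to compound 2, a step that the two limits leave unreadable from compound 1 to compound 3 and a step that the two limits leave unreadable from compound 2 to compound 3 therefore cannot be read for size or direction.

Compound 4 `Cc1ccc(-n2nncc2CN2C(=O)C3(C(C#N)=C(N)Oc4c3c3nc5ccccc5nc3c3ccccc43)c3ccccc32)cc1C` differs from compound 1 in one place: 3,4-dimethylphenyl in place of 4-methoxyphenyl on an aromatic nitrogen. Among the compounds with values here, none of the measured steps can be read, so nothing among them indicates that this change would move the value into the readable range. The expectation for compound 4 is that it stays where compound 1 stands (the limit of > 50000 nM in this assay, at which 3 of the 3 values shown sit), giving an estimated step that the limit leaves unreadable from compound 1 to compound 4. Compound 4 is therefore expected to give about 60000 nM in this assay, within an estimated range from 15000 nM to 250000 nM.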

Compound 4, half-maximal inhibitory concentration: > 50000 nM
Compound 4: a limit, no number; the forecaster's own chance of this, stated with the estimate: 85%; the middle value does not contradict the limit.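

In this assay compound 4 gives > 50000 nM, a limit of the assay. Its steps from compound 1, compound 2 and compound 3 therefore cannot be read for size or direction: the limit of > 50000 nM in this assay, at which 4 of the 4 values shown sit.

The compounds shown leave open whether any group on this aromatic nitrogen would give a readable value in this assay.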